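The compounds below may be only part of what the source reports. "The series", "measured", "known", "first", "only" and "open" are said of these compounds alone.

Measured compounds:
Compound 1 `N#CC1=C(N)Oc2c(N)cc3nc4ccccc4nc3c2C12C(=O)N(Cc1cnnn1-c1ccccc1Br)c1ccccc12` gives 27400 nM in a functional assay on A549 cells (Homo sapiens) for antiproliferative activity, read by MTT assay, with a stated time of 48 h; a higher number here means a weaker inhibitor, a lower number a stronger inhibitor.
Compound 2 `COc1ccc(-n2nncc2CN2C(=O)C3(C(C#N)=C(N)Oc4c(N)cc5nc6ccccc6nc5c43)c3ccccc32)cc1` gives > 50000 nM in this assay, which is a limit.
Compound 3 `CCOc1ccc(-n2nncc2CN2C(=O)C3(C(C#N)=C(N)Oc4c(N)cc5nc6ccccc6nc5c43)c3ccccc32)cc1` gives > 50000 nM in this assay, again a limit.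

Compound 3 therefore stands at the edge of what this assay can report, sharing that position as described by the limit of > 50000 nM in this assay, at which 2 of the 3 values shown sit. Compound 4 `Cc1ccc(-n2nncc2CN2C(=O)C3(C(C#N)=C(N)Oc4c(N)cc5nc6ccccc6nc5c43)c3ccccc32)cc1C` differs from it by 3,4-dimethylphenyl in place of 4-ethoxyphenyl on an aromatic nitrogen. Among the compounds with values here, the steps that bear on this change are an at least 1.8-fold higher number from compound 1 to compound 2 (0.26 log units; that floor lies within the scatter) and an at least 1.8-fold higher number from compound 1 to compound 3 (0.26 log units; that floor lies within the scatter), while a step that the two limits leave unreadable from compound 2 to compound 3. Every change at this aromatic nitrogen so far has moved the number up to the limit, so no improvement beyond the scatter is expected here. Compound 4 is estimated at 55000 nM, between 20000 nM and 150000 nM. The expected step is a step that the limit leaves unreadable from compound 3 to compound 4.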

Compound 4, half-maximal inhibitory concentration: > 50000 nM
Compound 4 was reported as a limit (the forecaster's own chance of this, stated with the estimate: 70%); the middle value is on the limit's open side.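

Compound 4 carries 3,4-dimethylphenyl, with no hydrogen-bond acceptor, in place of 4-ethoxyphenyl, and its result is still a limit: the limit of > 50000 nM in this assay, at which 3 of the 4 values shown sit.

Within the data shown here, the only readable comparison is an at least 1.8-fold higher number from compound 1 to compound 4 (0.26 log units; that floor lies within the scatter). The steps among compound 2, compound 3 and compound 4 cannot be read, as both ends of each are limits.

Among these compounds, still open is how far compound 4 lies past its limit, and whether 2-bromophenyl is the only group here to give a measured number. An amine or a carboxylic acid on this phenyl ring remains untested among the compounds shown.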